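The source may hold more compounds than are shown below. What is called first, only, known or untested is meant among the compounds shown, and "the series" means these compounds.

Measured compounds:
compound 1 `Nc1ccccc1NC(=O)c1ccc(CSC(=S)N2CCCc3ccccc32)cc1` gives 26.5% in a functional assay on A-375 cells (Homo sapiens) for antiproliferative activity, read by CCK-8 assay, with a stated time of 72 h, tested at 2 uM; a lower number here means a weaker effect, a higher number a stronger effect of the compound at the concentration tested;
compound 2 `Nc1ccccc1NC(=O)c1ccc(CSC(=S)N2CCN(c3cccnc3)CC2)cc1` gives 40.5%;
compound 3 `Nc1ccccc1NC(=O)c1ccc(CSC(=S)N2CCN(c3cnccn3)CC2)cc1` gives 29.1%.

Compound 1 stands at the low end of these three numbers. Its nearest neighbour is compound 3, whose value lies within the usual scatter of compound 1, so the two cannot be ranked. Compound 2 lies beyond the scatter, noticeably higher than compound 1. Among the compounds with values here, the single measured step, a number 11.4 percentage points lower from compound 2 to compound 3 (beyond the scatter), changes a group on an amine nitrogen in a ring, a different place from the one altered here.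

Compound 4 `Nc1ccccc1NC(=O)c1ccc(CSC(=S)N2CCc3ccccc32)cc1` differs from compound 1 by 2,3-dihydro-1H-indol-1-yl in place of 1,2,3,4-tetrahydroquinolin-1-yl on a thiocarbonyl carbon. Within the data shown here, no measured step touches this part of the core, so nothing beyond the scatter is expected: the expected step is a number 0.5 percentage points higher from compound 1 to compound 4 (within the scatter), and compound 4 is estimated at 27%, between 14% and 40%.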

Compound 4, a percentage reported as inhibition, at one concentration (the size of the read-out at that concentration, not a potency): 25.7%
For compound 4 the middle estimate is 1.3 percentage points above the measured one; the measured number falls inside the stated range.
By their numbers in this assay, from the lowest: compounds 4, 1 and 3 (each within the scatter of the next); then compound 2.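

Within the data shown here, replacing 1,2,3,4-tetrahydroquinolin-1-yl with 2,3-dihydro-1H-indol-1-yl on a thiocarbonyl carbon gives a number 0.8 percentage points lower from compound 1 to compound 4 (within the scatter) in this assay, the only measured step at this place. Changing the six-membered non-aromatic ring to a five-membered one therefore makes no readable difference to this single-concentration read-out. No supporting data bear on this result. On these data alone, it remains open whether a group without a fused aromatic ring on the thiocarbonyl carbon, such as diethylamino or morpholin-4-yl, would move the number beyond the scatter. As far as these compounds go, whether compound 1 and compound 4 would separate at other concentrations also remains open.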